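Chain Length and Ring Addition in Acetylhydrolase Inhibition

The source may report more compounds than this note shows. Statements on the series, on what has been measured and on what is new or still open speak of the compounds shown alone.

Of the compounds shown here, three sharing one core have been measured in a functional assay on a cell-free system (plasma) for inhibition of platelet-activating factor acetylhydrolase (Homo sapiens), tested at 100 nM; a higher number here means more inhibition at the concentration tested (going by the name of the read-out), a lower number less inhibition. Compound 1 `CCCCCCCCN(C)C(=O)Cn1cc(Cc2cnc(=O)n(C)c2)c(=O)nc1SCc1ccc(F)cc1` gives 55%. Compound 2 `CCCCCCCCCCCCN(C)C(=O)Cn1cc(Cc2cnc(=O)n(C)c2)c(=O)nc1SCc1ccc(F)cc1` gives 75%. Compound 3 `CCCCCCCCN(C)C(=O)Cn1cc(Cc2cnc(=O)n(CC(=O)N3CCNC(=O)C3)c2)c(=O)nc1SCc1ccc(F)cc1` gives 80%.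

Two single changes have been measured. The first is butyl in place of hydrogen on a saturated chain carbon, eight bonds along the chain from an amide-type nitrogen and it made a step of a number 20 percentage points higher from compound 1 to compound 2 (beyond the scatter). The second is (3-oxopiperazin-1-yl)carbonyl in place of hydrogen on a saturated chain carbon bound to an aromatic nitrogen and it made a step of a number 25 percentage points higher from compound 1 to compound 3 (beyond the scatter). Compound 2 and compound 3 lie within the scatter of each other, so no order between them is claimed.

Compound 4 `CCCCCCCCCCCCN(C)C(=O)Cn1cc(Cc2cnc(=O)n(CC(=O)N3CCNC(=O)C3)c2)c(=O)nc1SCc1ccc(F)cc1` remains to be measured in this assay. It differs from compound 3 by butyl in place of hydrogen on a saturated chain carbon, eight bonds along the chain from an amide-type nitrogen, the same change already seen from compound 1 to compound 2, at the same place. The two cores differ by (3-oxopiperazin-1-yl)carbonyl in place of hydrogen on a saturated chain carbon bound to an aromatic nitrogen.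

Because compound 1 and compound 2 showed a number 20 percentage points higher from compound 1 to compound 2 (beyond the scatter), the same change is expected to give compound 4 a higher number than compound 3, but the step is estimated smaller, a number 9 percentage points higher from compound 3 to compound 4 (within the scatter), since compound 3 already starts from 80% and the number in this assay has little room to go higher. Compound 4 is therefore estimated at 89%, with a likely range from 78% to 97%.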

Compound 4, a percentage reported as inhibition, at one concentration (the size of the read-out at that concentration, not a potency): 86%
For compound 4 the middle estimate is 3 percentage points above the measured one, and the stated range covers the measured number.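

In this assay, butyl on the core that carries the (3-oxopiperazin-1-yl)carbonyl group gave a number 6 percentage points higher from compound 3 to compound 4 (within the scatter), and this step cannot be told apart from the earlier butyl step: the same change on two cores in this assay, a number 20 percentage points higher (beyond the scatter) from compound 1 to compound 2 and a number 6 percentage points higher (within the scatter) from compound 3 to compound 4, 14 percentage points apart, within the scatter of two such steps The (3-oxopiperazin-1-yl)carbonyl change, carried onto the core that already has the butyl extension, gave a number 11 percentage points higher from compound 2 to compound 4 (beyond the scatter), and again the two steps cannot be told apart: the same change on two cores in this assay, a number 25 percentage points higher (beyond the scatter) from compound 1 to compound 3 and a number 11 percentage points higher (beyond the scatter) from compound 2 to compound 4, 14 percentage points apart, within the scatter of two such steps So neither change is shown to behave differently on the second core, but this does not show that the steps are equal, and it rests on only four compounds read at a single concentration, with the butyl step on compound 3 itself inside the scatter.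

The compounds shown leave open how a longer chain, or an amine or a carboxylic acid in place of the (3-oxopiperazin-1-yl)carbonyl group, would read in this assay. They also leave open how these compounds rank in potency, as the read-out gives inhibition at one concentration only.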